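Swapping Ethyl for Methylsulfanyl on the Shared Core

The source may hold more compounds than are shown below. What is called first, only, known or untested is meant among the compounds shown, and "the series" means these compounds.

Three compounds share one core and differ only in a single group on an aromatic carbon. Compound 1 `O=C(/C=C/c1ccc2c(c1)B(O)OC2)c1ccc(Cl)cc1` carries chloro, and in a functional assay on MDA-MB-231 cells (Homo sapiens) for cytotoxicity, read by MTT assay, with a stated time of 48 h (on this read-out higher numbers stand for weaker inhibition and lower numbers for stronger inhibition), compound 1 gives 7900 nM. Compound 2 `O=C(/C=C/c1ccc2c(c1)B(O)OC2)c1ccc(Br)cc1` carries bromo; in this assay compound 2 gives 9500 nM. Compound 3 `CCc1ccc(C(=O)/C=C/c2ccc3c(c2)B(O)OC3)cc1` carries ethyl, and in this assay compound 3 gives 9800 nM. Compound 3 has the highest of the three numbers, yet the steps to it are small: a 1.2-fold higher number from compound 1 to compound 3 (0.09 log units; within the scatter) and a 1.0-fold higher number from compound 2 to compound 3 (0.01 log units; within the scatter), while the two halogens differ by a 1.2-fold higher number from compound 1 to compound 2 (0.08 log units; within the scatter). All three steps lie within the scatter, so the three compounds cannot be told apart on these numbers.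

Compound 4 `CSc1ccc(C(=O)/C=C/c2ccc3c(c2)B(O)OC3)cc1` differs from compound 3 by methylsulfanyl in place of ethyl on an aromatic carbon. The measured steps bear on this change only loosely: each of them exchanged one small group for another at the same place, and each stayed within the scatter. On that basis compound 4 is expected to remain close to compound 3, with an estimated step of a 1.0-fold lower number from compound 3 to compound 4 (0.01 log units; within the scatter) in this assay and no direction beyond the scatter. The estimate for compound 4 in this assay is 9500 nM, with a range from 4500 nM to 20000 nM.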

Compound 4, half-maximal inhibitory concentration: 9800 nM
The estimate for compound 4 lay 1.0-fold (0.01 log units) below the measured number; the range from low to high includes it.
By their numbers in this assay, from the lowest: compounds 1, 2, 3 and 4 (each within the scatter of the next).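

Methylsulfanyl is the first group in this series to place a sulfur atom on this aromatic carbon, para to a large group, and it brings a hydrogen-bond acceptor that ethyl does not have, yet in this assay the exchange gives (no change at the digits printed from compound 3 to compound 4 (within the scatter)). The comparisons with the two halogens read the same way, with (a 1.0-fold higher number from compound 2 to compound 4 (0.01 log units; within the scatter)) for methylsulfanyl in place of bromo and (a 1.2-fold higher number from compound 1 to compound 4 (0.09 log units; within the scatter)) for methylsulfanyl in place of chloro, so chloro, bromo, ethyl and methylsulfanyl cannot be told apart at this position on these numbers. Nothing shown here bears on the reason for this result.

Since every step among these four compounds lies within the scatter, they do not show which kind of group at this position, if any, would produce a step beyond it. On these data alone, whether an amine, a carboxylic acid or a longer chain on this aromatic carbon would separate from these four in this assay remains open, as does whether a change elsewhere on the shared core would matter more.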